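A few compounds are considered here, and "the series" means these few. Any claim that something is new, unique, unknown or untested is made for them only; others in the source may bear on it.

Compound 1, with the structure `CC(C)[C@H](NC(=O)COc1cccc2ccccc12)C(=O)N[C@@H](CC(=O)O)C(=O)COc1ccccc1C(F)(F)F`, is one of three measured compounds sharing a core in which a naphthalene-bearing amide, a valine-derived unit and an acid-bearing unit end in a ketone carrying an aryloxy group. In a functional assay with Homo sapiens as the target (a higher number here means a weaker inhibitor, a lower number a stronger inhibitor), compound 1 gives 17300 nM, the lowest of the three numbers, though every neighbour lies within the scatter of it. Compound 2, `CC(C)[C@H](NC(=O)COc1cccc2ccccc12)C(=O)N[C@@H](CC(=O)O)C(=O)COc1ccc(C#N)cc1`, gives 26700 nM in this assay, and compound 3, `CC(C)[C@H](NC(=O)COc1cccc2ccccc12)C(=O)N[C@@H](CC(=O)O)C(=O)COc1ccc([N+](=O)[O-])cc1`, gives 22800 nM. The step of a 1.5-fold higher number from compound 1 to compound 2 (0.19 log units; within the scatter) and the step of a 1.3-fold higher number from compound 1 to compound 3 (0.12 log units; within the scatter) both exchange the 2-(trifluoromethyl)phenyl for another substituted phenyl and stay within the scatter, as does a 1.2-fold lower number from compound 2 to compound 3 (0.07 log units; within the scatter).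

Compound 4, `CC(C)[C@H](NC(=O)COc1cccc2ccccc12)C(=O)N[C@@H](CC(=O)O)C(=O)COc1ccc(F)cc1`, differs from compound 1 in one place: 4-fluorophenyl in place of 2-(trifluoromethyl)phenyl on an oxygen on a saturated carbon. The two comparable exchanges already measured bear directly on this one, and neither moved the number beyond the scatter, so no step beyond the scatter is expected here either, in no particular direction. Compound 4 is therefore estimated at 21000 nM in this assay, with a range from 8000 nM to 55000 nM, which means an expected step of a 1.2-fold higher number from compound 1 to compound 4 (0.08 log units; within the scatter).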

Compound 4, half-maximal inhibitory concentration: 14300 nM
Compound 4: the middle estimate sits 1.5-fold (0.17 log units) above what was measured; low and high end bracket the measured number.
By their numbers in this assay, from the lowest: compounds 4, 1, 3 and 2 (each within the scatter of the next).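

At this place, on an oxygen on a saturated carbon, the smaller 4-fluorophenyl, with fewer heavy atoms than 2-(trifluoromethyl)phenyl, gives a 1.2-fold lower number from compound 1 to compound 4 (0.08 log units; within the scatter) and so extends the flat picture to a change in group size. Fluoro in place of nitro gives a 1.6-fold lower number from compound 3 to compound 4 (0.20 log units; within the scatter) and fluoro in place of cyano gives a 1.9-fold lower number from compound 2 to compound 4 (0.27 log units; within the scatter), so all four substituted phenyl groups now lie within the scatter of one another in this assay. No measurement beyond these numbers bears on this result.

Every group shown here is a substituted phenyl, so it remains open whether any change at this oxygen can move the number beyond the scatter. A cyclohexyl group in place of the phenyl, or an amine on the phenyl, would test this.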